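Methoxyamino in place of hydroxy(methyl)amino: compound 4

This account rests on a few compounds, and the source may have more. Where it says the series, first, only, none or still open, it means among the compounds named here.

Measured so far in an assay on isolated protein for inhibition of Apoptosis regulator Bcl-2 (Homo sapiens), read by fluorescence polarization, with stated times of 5 min and 10 min; a lower number here means a stronger inhibitor, a higher number a weaker inhibitor:
- compound 1, `CC(C)=CCCC1=CC[C@H](C(=O)N(C)O)[C@@H](c2ccccc2)C1`: 2100 nM
- compound 2, `CC(C)=CCCC1=CC[C@@H](C(=O)N(C)C)[C@H](c2ccccc2)C1`: compound 2 gives only a limit, > 23000 nM
- compound 3, `CC(C)=CCCC1=CC[C@@H](C(=O)N(C)O)[C@H](c2ccccc2)C1`: 2300 nM

Compound 1 and compound 3 are mirror images, and their values sit within the scatter of each other, a 1.1-fold higher number from compound 1 to compound 3 (0.04 log units; within the scatter), which is consistent with the fact that compounds 1 and 3 differ only in the configuration as drawn. For the measured compounds named here, the only other value is the limit of compound 2, (the limit of > 23000 nM in this assay, at which 1 of the 3 values shown sits), so compound 1 and compound 3 are the two compounds with numbers here.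

The step to be followed goes from compound 1 to compound 4, `CONC(=O)[C@H]1CC=C(CCC=C(C)C)C[C@@H]1c1ccccc1`. The change is methoxyamino in place of hydroxy(methyl)amino on a carbonyl carbon; cut one bond further out it reads hydroxy(methyl)carbamoyl to methoxycarbamoyl. Going by the values given here, the one measured step that bears on the amide-type nitrogen is an at least 10-fold lower number from compound 2 to compound 3 (1.00 log units; beyond the scatter), hydroxy in place of methyl on that nitrogen. In compound 4 the hydroxy on the nitrogen is gone and an oxygen-bound methyl takes its place, so in this assay a step in the weaker direction is expected, a 7.1-fold higher number from compound 1 to compound 4 (0.85 log units; beyond the scatter), though a limit rather than a number is a real possibility. Compound 4 is estimated at 15000 nM, with a range from 4000 nM to 50000 nM.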

Compound 4, inhibition constant: 2400 nM
Estimate against measurement, compound 4: 6.3-fold (0.80 log units) above; measured number below the stated range.
By their numbers in this assay, from the lowest: compounds 1, 3 and 4 (each within the scatter of the next). At a limit, above all of these: compound 2.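

In this assay, a 1.1-fold higher number from compound 1 to compound 4 (0.06 log units; within the scatter), so the numbers for hydroxy(methyl)amino and methoxyamino on this carbonyl carbon cannot be told apart. The earlier step, an at least 10-fold lower number from compound 2 to compound 3 (1.00 log units; beyond the scatter), left open whether the gain depended on a hydroxy on the amide-type nitrogen, and compound 4, which has no such hydroxy and carries the amide hydrogen and a methyl on oxygen instead, shows that in these compounds it does not. For the compounds shown here, compound 2, the one compound here with no oxygen in this group, gives only a limit, > 23000 nM, so among the four compounds a number is seen only where that oxygen is present, with no compound going against this.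

Nothing among the data shown explains why the two groups read alike in this assay. Open, going by these compounds, are how a longer chain on that oxygen, such as ethoxyamino, or a carboxylic acid in place of the whole group would read in this assay, and whether the mirror image of compound 4 would stand as close to it as compound 3 does to compound 1.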